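Swapping the Triazole Aryl Group in a Cytotoxicity Series

This account rests on a few compounds, and the source may have more. Where it says the series, first, only, none or still open, it means among the compounds named here.

Compound 1 `C=C1C(=O)[C@]23C[C@@]1(O)CC[C@H]2c1ccc(OS(=O)(=O)c2ccc(C)cc2)c(C)c1[C@@H]3Cn1cc(-c2ccccn2)nn1`: 2310 nM
Compound 2 `C=C1C(=O)[C@]23C[C@@]1(O)CC[C@H]2c1ccc(O)c(C)c1[C@@H]3Cn1cc(-c2ccccn2)nn1`: 1570 nM
Compound 3 `C=C1C[C@]23C[C@@]1(O)CC[C@H]2c1ccc(OS(=O)(=O)c2ccc(C)cc2)c(C)c1[C@@H]3Cn1cc(-c2ccc(C)cc2)nn1`: a limit, > 20000 nM

In a functional assay on A549 cells (Homo sapiens) for cytotoxicity, read by MTT assay, with a stated time of 4 days (a higher number here means a weaker inhibitor, a lower number a stronger inhibitor), compound 2 has the lowest of the two numbers shown, with compound 1 close by; the step of a 1.5-fold lower number from compound 1 to compound 2 (0.17 log units; within the scatter) lies within the scatter. For compound 3 the result is only a limit, not a number. Compound 4 `C=C1C(=O)[C@]23C[C@@]1(O)CC[C@H]2c1ccc(O)c(C)c1[C@@H]3Cn1cc(-c2ccc(OC)cc2)nn1` differs from compound 2 by 4-methoxyphenyl in place of pyridin-2-yl on an aromatic carbon. For the measured compounds named here, no measured step touches this position: the single measured step concerns the oxygen on the aromatic ring, and compound 3 differs from the others in more than one place, so nothing quantitative can be carried over. Compound 4 is therefore expected to sit close to compound 2, with a step of a 1.1-fold higher number from compound 2 to compound 4 (0.06 log units; within the scatter) that stays inside the scatter. The estimate for compound 4 is 1800 nM, between 600 nM and 6000 nM.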

Compound 4, half-maximal inhibitory concentration: 1250 nM
Estimate against measurement, compound 4: 1.4-fold (0.16 log units) above; the measured number falls inside the stated range.
By their numbers in this assay, from the lowest: compounds 4, 2 and 1 (each within the scatter of the next). At a limit, above all of these: compound 3.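

In this assay the aromatic carbon of the five-membered aromatic ring with 3 nitrogen now has a measured step of its own, with 4-methoxyphenyl in place of pyridin-2-yl giving a 1.3-fold lower number from compound 2 to compound 4 (0.10 log units; within the scatter) on an otherwise unchanged structure. For the compounds shown here, the assay therefore does not separate these two groups at this position, which the earlier compounds could not show; compound 3 differs from the others in more than one place.

As far as these compounds go, whether an amine, a carboxylic acid or a longer chain at this position would read the same remains open. No measurement shown bears on why these two groups read alike.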